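Solubility from compound 1 to compound 4

The source may report more compounds than this note shows. Statements on the series, on what has been measured and on what is new or still open speak of the compounds shown alone.

Compound 1 `CNc1nc(NCCN2CCNCC2)c2sc(-c3ccc(C(F)(F)F)cc3)cc2n1` gives 115 ug/mL in a physicochemical assay for solubility, in phosphate buffer, at pH 6.5; a lower number here means a less soluble compound, a higher number a more soluble compound
Compound 2 `CNc1nc(N)c2sc(-c3ccc(C(F)(F)F)cc3)cc2n1` gives 3.1 ug/mL
Compound 3 `CNc1nc(NC2CC2)c2sc(-c3ccc(C(F)(F)F)cc3)cc2n1` gives only a limit (< 5 ug/mL)

Compound 1 holds the highest number among these measurements. Compound 4 `CNc1nc(N2CCC(N)CC2)c2sc(-c3ccc(C(F)(F)F)cc3)cc2n1` carries 4-aminopiperidin-1-yl in place of its (2-(piperazin-1-yl)ethyl)amino on an aromatic carbon (4-aminopiperidin-1-yl in place of (2-(piperazin-1-yl)ethyl)amino on an aromatic carbon). Among the measured compounds shown here, two measured steps bear on this change, and both are large: a 37-fold lower number from compound 1 to compound 2 (1.57 log units; beyond the scatter) and an at least 23-fold lower number from compound 1 to compound 3 (1.36 log units; beyond the scatter). Neither compound 2 nor compound 3 keeps a six-membered non-aromatic ring, whereas compound 4 does. A modest fall in this assay is therefore expected, far smaller than those two steps. The expected change is a 2.3-fold lower number from compound 1 to compound 4 (0.36 log units; beyond the scatter). For compound 4 the estimate is 50 ug/mL, within an expected range of 15 ug/mL to 150 ug/mL.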

Compound 4, solubility: 17 ug/mL
Estimate against measurement, compound 4: 2.9-fold (0.47 log units) above; low and high end bracket the measured number.
By their numbers in this assay, from the lowest: compound 2; then compound 4; then compound 1.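

At this aromatic carbon, 4-aminopiperidin-1-yl keeps only part of the number held by (2-(piperazin-1-yl)ethyl)amino in this assay, with a 6.8-fold lower number from compound 1 to compound 4 (0.83 log units; beyond the scatter), yet it stays clearly above amino, with a 5.5-fold higher number from compound 2 to compound 4 (0.74 log units; beyond the scatter). It also stands above cyclopropylamino, with an at least 3.4-fold higher number from compound 3 to compound 4 (0.53 log units; beyond the scatter). That last step rests on compound 3, whose value is a limit: the limit of < 5 ug/mL in this assay, at which 1 of the 4 values shown sits.

Compound 4 differs from compound 1 in both the ring and the chain, and the compounds shown cannot separate these two changes. From the compounds shown here alone, whether piperazin-1-yl set directly on this carbon, or a longer chain ending in a primary amine, would come closer to compound 1 stays open.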